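The source may hold more compounds than are shown below. What is called first, only, known or untested is meant among the compounds shown, and "the series" means these compounds.

Compound 1 `Cc1c(OCCCCOc2ccccc2C(=O)O)ccc(C(=O)CC2CCCC2)c1C` gives 2580 nM.
Compound 2 `Cc1c(OCCCCOc2ccccc2C(=O)O)ccc(C(=O)CC2CCCC2)c1O` gives 335 nM.
Compound 3 `Cc1c(OCCCCOc2cccc(C(=O)O)c2)ccc(C(=O)CC(C)C)c1C` is reported as "not active" (no number reported).

Of the compounds shown here, three have been tested in an assay on HEK293 cells for positive allosteric modulation of metabotropic glutamate receptor 2 (Rattus norvegicus), read by thallium flux, with a stated time of 2.5 min; on this read-out lower numbers stand for an effect already at smaller amounts and higher numbers for an effect only at larger amounts of compound. Compound 1 gives 2580 nM, compound 2 gives 335 nM, and compound 3 is reported as "not active" (no number reported), without a number. Compound 2 therefore holds the lowest of the two numbers obtained. For the measured compounds named here, the only step that links two measured compounds, a 7.7-fold lower number from compound 1 to compound 2 (0.89 log units; beyond the scatter), comes from a hydroxy in place of methyl on an aromatic carbon.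

Compound 4 `Cc1c(OCCCCOc2ccc(F)c(C(=O)O)c2)ccc(C(=O)CC2CCCC2)c1O` has not yet been measured. It differs from compound 2 in one place: 3-carboxy-4-fluorophenyl in place of 2-carboxyphenyl on an oxygen on a saturated carbon. Going by the values given here, no measured step covers this kind of change. The step from compound 1 to compound 2 concerns another part of the molecule and says nothing about shifting the carboxylic acid or adding fluorine. Compound 3 carries its carboxylic acid at another place on its ring and was not active, but it also differs from compound 1 elsewhere, so it offers only a faint hint that such a shift may cost potency. On that thin basis, a loss is expected, a 4.5-fold higher number from compound 2 to compound 4 (0.65 log units; beyond the scatter), with wide uncertainty. Compound 4 is estimated at 1500 nM, in a range from 300 nM to 8000 nM.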

Compound 4, half-maximal effective concentration: 699 nM
For compound 4 the middle estimate is 2.1-fold (0.33 log units) above the measured one; the range from low to high includes it.
By their numbers in this assay, from the lowest: compound 2; then compound 4; then compound 1.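

In this assay, for the compounds shown here, this is the first measured change to the ring on an oxygen on a saturated carbon: 3-carboxy-4-fluorophenyl in place of 2-carboxyphenyl gives a 2.1-fold higher number from compound 2 to compound 4 (0.32 log units; beyond the scatter), a modest step beyond the usual scatter. The position therefore accepts this altered ring with only a modest loss, and a carboxylic acid away from its place in compound 2 does not by itself abolish the effect, something compound 3, which also differs elsewhere, could not show. No measurement available here explains why the number moves.

The new ring differs from the old one both in where its carboxylic acid stands and in carrying fluorine, and the compounds shown do not separate these two changes. Also open, going by these compounds, is how this position would respond to a tetrazole or an amide in place of the carboxylic acid, or to chlorine or a methoxy group in place of the fluorine, and whether the gain from hydroxy in place of methyl would hold with the new ring.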